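Nitro versus hydroxy on the benzyl ring, K562 series

A few compounds are considered here, and "the series" means these few. Any claim that something is new, unique, unknown or untested is made for them only; others in the source may bear on it.

Measured compounds:
compound 1 `CCOC(=O)N1CCC(N(Cc2cccc([N+](=O)[O-])c2)C(=O)N(C)C)CC1` gives 26000 nM
compound 2 `CCOC(=O)N1CCC(N(Cc2ccc(O)cc2)C(=O)N(C)C)CC1` gives 41800 nM

In a functional assay on K562 cells (Homo sapiens) for antiproliferative activity, read by MTT assay, with a stated time of 48 h (a lower number here means a stronger inhibitor, a higher number a weaker inhibitor), compound 1 gives 26000 nM and compound 2 gives 41800 nM. Among the measured compounds shown here, the single measured step, a 1.6-fold higher number from compound 1 to compound 2 (0.21 log units; within the scatter), exchanges both the group on the ring and the aromatic carbon that carries it, and it lies within the scatter. For the measured compounds named here, compound 2 holds the higher of the two numbers, but its only neighbour, compound 1, sits within the scatter of it, so no order between the two can be read.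

Compound 3 `CCOC(=O)N1CCC(N(Cc2ccc([N+](=O)[O-])cc2)C(=O)N(C)C)CC1` is not yet measured. The change from compound 2 to compound 3 is nitro in place of hydroxy on an aromatic carbon. Going by the values given here, only the step from compound 1 to compound 2 bears on it, and only in part, since that step also changed which aromatic carbon carries the group. Among the compounds with values here, nothing so far has moved the number beyond the scatter, and compound 3 carries the same nitro as compound 1, which gave 26000 nM. A step of no more than the scatter toward a lower number is therefore expected in this assay.

Compound 3 is expected to give about 28000 nM in this assay, with a range of 10000 nM to 80000 nM. That estimate means an expected step of a 1.5-fold lower number from compound 2 to compound 3 (0.17 log units; within the scatter).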

Compound 3, half-maximal inhibitory concentration: 26000 nM
For compound 3 the middle estimate is 1.1-fold (0.03 log units) above the measured one; the range from low to high includes it.
By their numbers in this assay, from the lowest: compounds 1, 3 and 2 (each within the scatter of the next).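

In this assay the step of a 1.6-fold lower number from compound 2 to compound 3 (0.21 log units; within the scatter) isolates nitro in place of hydroxy on one and the same aromatic carbon, which the earlier step could not do, and this exchange lies within the scatter. The step of no change at the digits printed from compound 1 to compound 3 (within the scatter) isolates the other part of that earlier change, the aromatic carbon that carries the nitro, and the printed numbers of the two nitro compounds are identical. Taken one at a time, neither the exchange of group nor the shift of the nitro separates these compounds in this series, and no measurement is at hand that bears on why the numbers lie so close.

From the compounds shown here alone, whether an amine or a carboxylic acid on this aromatic carbon would move the number beyond the scatter remains open. Also open, going by these compounds, is whether a hydroxy on the aromatic carbon that carries the nitro in compound 1 would match compound 2, and whether a longer chain between the ring and the amide-type nitrogen would change the picture.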